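The compounds below may be only part of what the source reports. "The series", "measured", "known", "first", "only" and "open" are said of these compounds alone.

Measured so far in an ADME assay on Huh-7 cells (Homo sapiens) for cytotoxicity; on this read-out higher numbers stand for lower toxicity in this test and lower numbers for higher toxicity in this test:
- compound 1, `CN1CCN(CCNCc2cn(-c3ccc(F)cc3F)nc2-c2ccc(Cl)cc2)CC1`, gives 19000 nM
- compound 2, `CCCN1CCC(CNCc2cn(-c3ccc([N+](=O)[O-])cc3)nc2-c2ccc(OC(F)(F)F)cc2)CC1`, gives 18000 nM

Compound 1 and compound 2 lie within the usual scatter of each other in this assay, so on the numbers in hand nothing sets compound 1 apart from compound 2, and no ordering of the two can be read from them. Going by the values given here, only these two values exist, and no step between compounds that differ in a single place has been measured, so there is no direct calibration for any single structural change in this assay.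

Compound 3, `CN1CCN(CCNCc2cn(-c3ccc(F)cc3F)nc2-c2cccc(Cl)c2)CC1`, has not yet been measured. Against compound 1 the difference is 3-chlorophenyl in place of 4-chlorophenyl on an aromatic carbon, with the chlorine carried on a 3-chlorophenyl rather than a 4-chlorophenyl; the two compounds have the same atoms, joined differently.

Among the compounds with values here, with no measured step of this kind to lean on, the expectation is a step of essentially no size, in no particular direction, within the scatter: no change at the digits printed from compound 1 to compound 3 (within the scatter) is the estimated step. Compound 3 is accordingly expected to give about 19000 nM in this assay, with a range from 9000 nM to 40000 nM, anchored on compound 1 at 19000 nM.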

Compound 3, half-maximal cytotoxic concentration: 15000 nM
Compound 3: the middle estimate sits 1.3-fold (0.10 log units) above what was measured, within the range that was stated.
By their numbers in this assay, from the lowest: compounds 3, 2 and 1 (each within the scatter of the next).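

In this assay, going by these compounds alone, the one single-place step at hand is a 1.3-fold lower number from compound 1 to compound 3 (0.10 log units; within the scatter), so 3-chlorophenyl in place of 4-chlorophenyl on this aromatic carbon, next to the ring nitrogen, gives no separation that can be read from the scatter. The two compounds have the same atoms, joined differently, which makes this a direct test of where the chlorine sits on this phenyl group; for this pair, on the core and side chain of compound 1, the chlorine's location leaves the read-out indistinguishable. Nothing at hand bears on what lies behind this result.

This covers one relocation of one chlorine, with the 2,4-difluorophenyl group and the side chain held fixed, so it does not show whether the position would tolerate other groups, such as a carboxylic acid or an amine on the phenyl ring in place of the chlorine. Compound 2 differs from compound 1 and compound 3 in more than one place, so it cannot show whether the same holds with its trifluoromethoxy and nitro groups and its side chain.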